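This account rests on a few compounds, and the source may have more. Where it says the series, first, only, none or still open, it means among the compounds named here.

Measured in a functional assay on L02 cells (Homo sapiens) for inhibition, read by Griess assay, with stated times of 1 h and 24 h; on this read-out higher numbers stand for weaker inhibition and lower numbers for stronger inhibition:
- Compound 1 `CCCc1nn(C)c2c(NC3CC3)nc(/C=C/c3nc(C)c(C)nc3C)nc12` gives 706000 nM
- Compound 2 `CCCc1nn(C)c2c(NCc3ccc(F)cc3)nc(CCc3cccnc3)nc12` gives < 40000 nM, a limit
- Compound 3 `CN(C)c1nc(/C=C/c2ccccc2)nc2ccsc12` gives > 1000000 nM, a limit

Compound 3 has no exact number, and its limit of > 1000000 nM is the highest figure shown, on a read-out where higher means weaker inhibition. Compound 4 `Brc1ccc(Nc2nc(/C=C/c3ccccc3)nc3ccsc23)cc1` carries (4-bromophenyl)amino in place of dimethylamino on an aromatic carbon. Going by the values given here, no measured pair isolates this change, so the expectation is loose. It leans on compound 2, a compound with a different core and a ring-bearing amino group, whose limit is < 40000 nM. The expected step is an at least 5.0-fold lower number from compound 3 to compound 4 (0.69 log units; beyond the scatter), towards stronger inhibition and beyond the usual scatter. For compound 4 the estimated value is 200000 nM, with an expected range of 30000 nM to 1000000 nM.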

Compound 4, half-maximal inhibitory concentration: > 1000000 nM
Compound 4: only a limit was reported; the forecaster's own chance of this, stated with the estimate: 35%; middle value at least 5.0-fold (0.69 log units) from the limit.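

Going by these compounds alone, compound 3 and compound 4 each gave only a limit, not an exact number, so no step between them can be read. The compounds shown leave open whether (4-bromophenyl)amino in place of dimethylamino changes inhibition at all.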